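A few compounds are considered here, and "the series" means these few. Any claim that something is new, unique, unknown or untested is made for them only; others in the source may bear on it.

Measured in a functional assay on HT-29 cells (Homo sapiens) for inhibition, read by sulforhodamine B assay, with a stated time of 48 h; a lower number here means a stronger inhibitor of growth, a higher number a weaker inhibitor of growth:
- compound 1 (`O=C(CCl)NC(=O)Nc1ccc(C2CCCCC2)cc1`) gives 2300 nM
- compound 2 (`O=C(CCl)NC(=O)Nc1ccc(OC2CCCC2)cc1`) gives 3100 nM
- compound 3 (`CC(C)(C)c1ccc(NC(=O)NC(=O)CCl)cc1`) gives 3300 nM

Compound 3 cannot be separated from the other two compounds on these numbers. The steps that reach it are small (a 1.4-fold higher number from compound 1 to compound 3 (0.16 log units; within the scatter) and a 1.1-fold higher number from compound 2 to compound 3 (0.03 log units; within the scatter)), and the remaining step is of the same kind (a 1.3-fold higher number from compound 1 to compound 2 (0.13 log units; within the scatter)). Cyclohexyl, cyclopentyloxy and tert-butyl are therefore not distinguished here.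

The next compound is compound 4 (`Cc1ccc(NC(=O)NC(=O)CCl)cc1`), which carries methyl in place of tert-butyl on an aromatic carbon, para to a group of 8 heavy atoms (methyl in place of tert-butyl on an aromatic carbon).

The two steps into compound 3 bear most directly on this change, but neither ends in a group as small as methyl, so the data do not cover it directly. Their flatness argues against a large move, while the untested reduction to methyl leaves room for some weakening. A modest shift towards a higher number, meaning weaker growth inhibition, is expected, and it may not clear the scatter by much.

The estimated step is a 2.0-fold higher number from compound 3 to compound 4 (0.29 log units; within the scatter) for this change.

Compound 4 is estimated at 6500 nM (expected range 2800 nM to 15000 nM).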

Compound 4, concentration for 50% growth inhibition: 10000 nM
Estimate against measurement, compound 4: 1.5-fold (0.19 log units) below, and the stated range covers the measured number.
By their numbers in this assay, from the lowest: compounds 1, 2 and 3 (each within the scatter of the next); then compound 4.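

Methyl on this aromatic carbon is the first change in the series to clear the scatter in this assay and it does so against each of the larger groups: a 3.0-fold higher number from compound 3 to compound 4 (0.48 log units; beyond the scatter) when it replaces tert-butyl and a 3.2-fold higher number from compound 2 to compound 4 (0.51 log units; beyond the scatter) when it replaces cyclopentyloxy and a 4.3-fold higher number from compound 1 to compound 4 (0.64 log units; beyond the scatter) when it replaces cyclohexyl. The position is therefore not indifferent to what it carries: the level stretch across cyclohexyl, cyclopentyloxy and tert-butyl does not extend to methyl, although all three steps share compound 4 as their end point and so rest on a single new value. Nothing measured alongside these numbers offers an account of this step.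

Ethyl or isopropyl at this position would show whether the weakening sets in gradually between tert-butyl and methyl or only at methyl itself. Open too, going by these compounds, is how a hydrogen, a methoxy group, an amine or a carboxylic acid on this carbon would compare with methyl and with the three larger groups.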